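Dropping the amino group from the fused core

A few compounds are considered here, and "the series" means these few. Any claim that something is new, unique, unknown or untested is made for them only; others in the source may bear on it.

Working notes on the series. In an assay on isolated protein for inhibition of MAP kinase-activated protein kinase 5 (Homo sapiens), read by mobility shift assay, tested at 30 uM (on this read-out higher numbers stand for more inhibition at the one concentration tested (going by the name of the read-out) and lower numbers for less inhibition), compound 1 `Cc1cc2[nH]nc(N)c2c(=O)[nH]1` gives 8%. Compound 2 `Nc1n[nH]c2cc(-c3cccs3)[nH]c(=O)c12` gives 12% and compound 3 `Nc1n[nH]c2cc(CC3CCNCC3)[nH]c(=O)c12` gives 3% in this assay, so compound 1 sits among three numbers that all lie within the usual scatter of one another. The step of a number 4 percentage points higher from compound 1 to compound 2 (within the scatter) comes with thiophen-2-yl in place of methyl on an aromatic carbon, and the step of a number 5 percentage points lower from compound 1 to compound 3 (within the scatter) with piperidin-4-yl in place of hydrogen on a saturated chain carbon bound to an aromatic carbon; both changes sit away from the amino group.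

Compound 4 `Cc1cc2[nH]ncc2c(=O)[nH]1` differs from compound 1 as follows: hydrogen in place of amino on an aromatic carbon. Among the measured compounds shown here, no measured step touches the amino group, so there is no direct precedent for its loss, and the two measured steps only show that the read-out in this assay has been flat across the changes tried. On that basis the step from compound 1 to compound 4 is expected to be small, a number 3 percentage points lower from compound 1 to compound 4 (within the scatter), with no direction beyond the scatter. Compound 4 is estimated at 5% in this assay, within a range of -10% to 20%.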

Compound 4, a percentage reported as inhibition, at one concentration (the size of the read-out at that concentration, not a potency): 1%
The estimate for compound 4 lay 4 percentage points above the measured number, within the range that was stated.
By their numbers in this assay, from the lowest: compounds 4, 3, 1 and 2 (each within the scatter of the next, the first and the last beyond it).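

Hydrogen in place of amino on an aromatic carbon of the five-membered aromatic ring gives the first measured change at this position: in this assay it comes with a number 7 percentage points lower from compound 1 to compound 4 (within the scatter) and so stays within the scatter. The amino group therefore joins the two earlier sites of change, and removing it shows no effect that this read-out can separate from scatter at the one concentration tested. No evidence on hand bears on this result.

Open is what a methylamino group or a carboxylic acid on the same carbon would give, since hydrogen is the only replacement for amino shown here. Also open, on these data alone, is whether the loss of amino reads the same with thiophen-2-yl in place of methyl, as in compound 2.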